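The compounds below may be only part of what the source reports. "The series", "measured", "known", "first", "only" and "open" are said of these compounds alone.

Going by the values given here, compound 1 `COC(=O)C1=C(C)NC(c2nccs2)=NC1(C)c1ccc(F)cc1` gives 22 ug/mL in a physicochemical assay for solubility, read by HPLC, in phosphate buffer, at pH 6.5 (on this read-out lower numbers stand for lower solubility and higher numbers for higher solubility), and stands as the lower of the two numbers measured so far. Compound 2 `COC(=O)C1=C(C)NC(c2nccs2)=NC1(C)c1ccc(S(C)(=O)=O)cc1`, which carries methylsulfonyl in place of fluoro on an aromatic carbon, gives 365 ug/mL in this assay, so that a 17-fold higher number from compound 1 to compound 2 (1.22 log units; beyond the scatter). Compound 3 `COC(=O)C1=C(C)NC(c2nccs2)=NC1(C)c1ccc(C#N)cc1` has not yet been measured in this assay; it differs from compound 1 in a single place: cyano in place of fluoro on an aromatic carbon. Among the compounds with values here, only one measured step bears on this change, the one from compound 1 to compound 2, and it was large; yet the group that enters there is not the one that enters here, so it serves as a loose guide rather than a match. Compound 3 is therefore expected to rise above compound 1 by a moderate step, a 2.7-fold higher number from compound 1 to compound 3 (0.44 log units; beyond the scatter). Compound 3 is estimated at 60 ug/mL, within a range from 20 ug/mL to 180 ug/mL.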

Compound 3, solubility: 87 ug/mL
Beside the measured number, compound 3's estimate is 1.5-fold (0.16 log units) below it; the measured number falls inside the stated range.
By their numbers in this assay, from the lowest: compound 1; then compound 3; then compound 2.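

With cyano in place of fluoro, a 4.0-fold higher number from compound 1 to compound 3 (0.60 log units; beyond the scatter) in this assay, so a second group entering at this aromatic carbon, para to a large group, also moves the number upward, and the rise seen with methylsulfonyl no longer stands alone. The two entering groups are also distinguishable from each other, since a 4.2-fold lower number from compound 2 to compound 3 (0.62 log units; beyond the scatter), which places compound 3 between the other two and shows that the size of the rise depends on which group enters. No measurement shown explains this difference between cyano and methylsulfonyl. The compounds shown leave open how an amine or a carboxylic acid at this same place would compare with these groups. They also leave open whether the same order would hold on a core changed elsewhere, for instance with a longer chain in place of the methyl ester.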